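The source may hold more compounds than are shown below. What is called first, only, known or untested is meant among the compounds shown, and "the series" means these compounds.

Working notes on the series.

Of the compounds shown here, three have been measured in a functional assay on CHO cells with metabotropic glutamate receptor 2 (Homo sapiens) as the target, read by GTPgammaS binding; on this read-out higher numbers stand for an effect only at larger amounts of compound and lower numbers for an effect already at smaller amounts. Compound 1 `N#Cc1c(-c2ccc(NC3CC3)c(Cl)c2)ccn2c(CC(F)(F)F)cnc12` gives 141 nM in this assay. Compound 2 `CCCc1cnc2c(C#N)c(N3CCN(c4ccccc4)CC3)ccn12` gives 977 nM in this assay. Compound 3 `CCCCn1ccc(N2CCN(c3nc(C)cc(C)n3)CC2)c(C#N)c1=O` gives 631 nM in this assay. Compound 2 has the highest number of the three; its number and that of compound 3 lie within the scatter of each other, so nothing can be said of their order, whereas the number of compound 1 lies beyond the scatter below that of compound 2. None of these pairs differs in only one place, so no single structural step can be read from the measured set.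

Compound 4 `CCCc1cnc2c(C#N)c(N3CCN(c4ncccn4)CC3)ccn12` has not been measured in this assay. It differs from compound 2 as follows: pyrimidin-2-yl in place of phenyl on an amine nitrogen in a ring. For the measured compounds named here, no measured pair shows this change, and the shared core of compound 2 and compound 4 is the same. The step from compound 2 to compound 4 is therefore expected to be small, most likely none beyond the scatter, in either direction: a 1.1-fold lower number from compound 2 to compound 4 (0.06 log units; within the scatter). Compound 4 is accordingly estimated at 850 nM in this assay, with a range from 300 nM to 2500 nM.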

Compound 4, half-maximal effective concentration: > 3160 nM
Compound 4: a limit, no number; the forecaster's own chance of this, stated with the estimate: 5%; middle value at least 3.7-fold (0.57 log units) away from the limit.
By their numbers in this assay, from the lowest: compound 1; then compounds 3 and 2 (each within the scatter of the next). At a limit, above all of these: compound 4.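

Pyrimidin-2-yl in place of phenyl on an amine nitrogen in a ring gives the first single-place step in the series: an at least 3.2-fold higher number from compound 2 to compound 4 (0.50 log units; beyond the scatter). In this assay compound 4 stands at a limit and not at a number: the limit of > 3160 nM in this assay, at which 1 of the 4 values shown sits. The step therefore fixes only a lower bound on its size, yet it shows that this place does not tolerate every exchange of one six-membered aromatic ring for another with the same heavy-atom count, as here the ring gains 2 nitrogen and 2 hydrogen-bond acceptors.

From the compounds shown here alone, whether one ring nitrogen is enough for such a step remains open, and a pyridin-2-yl group at this place would speak to that. Also open, going by these compounds, is how a phenyl ring carrying a methoxy group or a fluorine would read here.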